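Swapping the Pyridinyl Arm for a Cyanophenyl Arm

The source may hold more compounds than are shown below. What is called first, only, known or untested is meant among the compounds shown, and "the series" means these compounds.

Compound 1 `O=C(Nc1ccccc1)N(Cc1ccccn1)n1cnnc1` has the lowest of the three numbers in a functional assay on B16-F10 cells (Mus musculus) for cytotoxicity, read by MTT assay, with a stated time of 48 h (on this read-out higher numbers stand for weaker inhibition and lower numbers for stronger inhibition), giving 23700 nM, though all three sit within the usual scatter of one another. Compound 2 `Cc1ccc(NC(=O)N(Cc2ccccn2)n2cnnc2)cc1` gives 35200 nM and compound 3 `O=C(NC1CCCCC1)N(Cc1ccccn1)n1cnnc1` gives 35800 nM; the steps are a 1.5-fold higher number from compound 1 to compound 2 (0.17 log units; within the scatter) and a 1.5-fold higher number from compound 1 to compound 3 (0.18 log units; within the scatter). Compound 4 `N#Cc1ccc(CN(C(=O)Nc2ccccc2)n2cnnc2)cc1` differs from compound 1 in one place: 4-cyanophenyl in place of pyridin-2-yl on a saturated chain carbon bound to an amide-type nitrogen. Both measured steps alter the group on the amide-type nitrogen, not the chain carbon where this change sits, so neither speaks directly to it; they show only that small edits elsewhere left the read-out unmoved. The expectation is therefore a step no larger than the scatter, in either direction. Compound 4 is expected to give 25000 nM, within 8000 nM to 80000 nM. That estimate means an expected step of a 1.1-fold higher number from compound 1 to compound 4 (0.02 log units; within the scatter).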

Compound 4, half-maximal inhibitory concentration: 34700 nM
Compound 4: the middle estimate sits 1.4-fold (0.14 log units) below what was measured; the range from low to high includes it.
By their numbers in this assay, from the lowest: compounds 1, 4, 2 and 3 (each within the scatter of the next).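

In this assay, for the compounds shown here, the first step at the saturated chain carbon bound to an amide-type nitrogen, 4-cyanophenyl in place of pyridin-2-yl, gives a 1.5-fold higher number from compound 1 to compound 4 (0.17 log units; within the scatter). So this position accepts a larger aromatic ring of carbon only, carrying a nitrile, without the number leaving the scatter. Nothing measured here explains this outcome. Still open, from the compounds shown here alone, is whether an amine, a carboxylic acid or a longer chain in place of pyridin-2-yl would move the number beyond the scatter.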